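Trading the benzyl for hydrogen on compound 3

This account rests on a few compounds, and the source may have more. Where it says the series, first, only, none or still open, it means among the compounds named here.

compound 1 `COc1ccc2[nH]c(-c3cc(OC)c(OC)c(OC)c3)cc2c1`: > 30000 nM, a limit
compound 2 `COc1ccc2c(c1)cc(-c1cc(OC)c(OC)c(OC)c1)n2Cc1ccccc1`: > 30000 nM, a limit
compound 3 `COc1ccc2c(c1)cc(-c1cc(OC)c(OC)c(OC)c1)n2Cc1ccc(OCc2ccccc2)cc1`: > 30000 nM, a limit

All three compounds were tested in a functional assay on PC-3 cells (Homo sapiens) for cytotoxicity, read by MTT assay, with a stated time of 24 h (on this read-out higher numbers stand for weaker inhibition and lower numbers for stronger inhibition), and none returned a number. Compound 3 therefore stands only at a limit, > 30000 nM. The same is true of compound 1 and compound 2, so the three cannot be ranked.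

The next compound, compound 4 `COc1ccc2c(c1)cc(-c1cc(OC)c(OC)c(OC)c1)n2Cc1ccc(O)cc1`, differs from compound 3 in one place: hydrogen in place of benzyl on an oxygen on an aromatic ring. In short, benzyloxy becomes hydroxy.

The nearest measured change is a step that the two limits leave unreadable from compound 2 to compound 3, where benzyloxy took the place of hydrogen on an aromatic carbon. The other measured change, a step that the two limits leave unreadable from compound 1 to compound 2, added a benzyl on an aromatic nitrogen. Neither gives a size to carry forward, and the whole record is the limit of > 30000 nM in this assay, at which 3 of the 3 values shown sit.

With compound 3 at > 30000 nM and no readable step behind it, no step beyond the scatter can be expected in either direction, and compound 4 is expected to stay at or near the same limit. The expected move is a number no higher from compound 3 to compound 4 (the limit leaves the size open), an estimate with no measured size behind it. For compound 4 the estimated value is 30000 nM, with an expected range from 10000 nM to 60000 nM.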

Compound 4, half-maximal inhibitory concentration: > 30000 nM
Compound 4: only a limit was reported (the forecaster's own chance of this, stated with the estimate: 80%); the middle value sits exactly at the limit.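

In this assay compound 4 gives > 30000 nM as a limit and not a number. Among the compounds shown here, no step among compound 1, compound 2, compound 3 and compound 4 can be read, because the record holds limits only: the limit of > 30000 nM in this assay, at which 4 of the 4 values shown sit. The compounds shown leave open whether any of these changes alters inhibition at all, and how the four compounds rank.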